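Benzyl to Butyl: What to Expect for Compound 4

This account rests on a few compounds, and the source may have more. Where it says the series, first, only, none or still open, it means among the compounds named here.

Measured so far in a functional assay on A549 cells (Homo sapiens) for antiproliferative activity, read by trypan blue exclusion, with a stated time of 72 h, tested at 20 uM; a higher number here means more inhibition at the concentration tested (going by the name of the read-out), a lower number less inhibition:
compound 1 `O=C1NC(=O)N(Cc2ccccc2)/C1=C/c1ccccc1` gives 2.9%
compound 2 `O=C1NC(=O)N(Cc2ccccc2)/C1=C\c1ccccc1` gives 42%
compound 3 `O=C1NC(=O)N(Cc2ccccc2)/C1=C/c1ccc(O)cc1` gives 41%

Compound 1 stands lowest of the three in this assay, with compound 3 nearest and compound 2 furthest, both well beyond the scatter above it. Redrawing the double bond from one configuration to the other gives a number 39.1 percentage points higher from compound 1 to compound 2 (beyond the scatter), a step that can be tied to the geometry itself because of the fact that compounds 1 and 2 differ only in the configuration as drawn. Adding a hydroxy to the aromatic ring gives a number 38.1 percentage points higher from compound 1 to compound 3 (beyond the scatter).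

Compound 4 `CCCCN1C(=O)NC(=O)/C1=C\c1ccccc1` differs from compound 1 in another place entirely: propyl in place of phenyl on a saturated chain carbon bound to an amide-type nitrogen in a ring. Neither measured step touches that part of the molecule; the first changes the double bond, the second decorates the other aromatic ring. So nothing among the measured compounds shows how this assay answers a change on the chain bound to the ring nitrogen, and the direction of the step is open. With compound 1 already near the bottom of the scale, a step within the scatter or a modest rise seems the most reasonable expectation; the step expected is a number 7.1 percentage points higher from compound 1 to compound 4 (within the scatter).

Compound 4 is therefore estimated at 10%, within a range from 0% to 35%.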

Compound 4, a percentage reported as inhibition, at one concentration (the size of the read-out at that concentration, not a potency): 6.8%
For compound 4 the middle estimate is 3.2 percentage points above the measured one; the range from low to high includes it.
By their numbers in this assay, from the lowest: compounds 1 and 4 (each within the scatter of the next); then compounds 3 and 2 (each within the scatter of the next).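

Replacing phenyl with propyl on a saturated chain carbon bound to an amide-type nitrogen in a ring, which is the same change as benzyl to butyl, gives a number 3.9 percentage points higher from compound 1 to compound 4 (within the scatter) in this assay. Going by these compounds alone, this is the first reading at this position, and it shows that the phenyl can give way to an open chain with no difference beyond the scatter, something the earlier steps, made at the double bond and on the other aromatic ring, could not show. The one available explanatory fact concerns the double bond alone and offers no reason for this result.

Compound 1 gives 2.9%, which leaves little room for a drop to appear, so the same swap on compound 2 or compound 3, with their higher numbers, could read differently and remains an open question. On these data alone, how an amine, a carboxylic acid or a longer chain at this place would read in this assay is likewise open.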